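The source may report more compounds than this note shows. Statements on the series, on what has been measured and on what is new or still open speak of the compounds shown alone.

Measured compounds:
compound 1 `CC(C)c1ccc(OC(C)(Cc2cccc(Cl)c2)C(=O)O)cc1` — 5 mg/kg
compound 2 `CCCCc1cccc(CC(C)(Oc2ccc(C(C)C)cc2)C(=O)O)c1` — 1 mg/kg

In a functional assay on the whole organism for inhibition, with Rattus norvegicus as the target (a lower number here means that less compound is needed, a higher number that more compound is needed for the effect), compound 1 gives 5 mg/kg, the highest of the two numbers shown, while compound 2 gives 1 mg/kg. Going by the values given here, the only measured step is a 5.0-fold lower number from compound 1 to compound 2 (0.70 log units; beyond the scatter). Compound 3 `COc1ccccc1CC(C)(Oc1ccc(C(C)C)cc1)C(=O)O` differs from compound 1 by 2-methoxyphenyl in place of 3-chlorophenyl on a saturated chain carbon, two bonds along the chain from a carbonyl carbon and an oxygen on an aromatic ring. Among the compounds with values here, no measured step bears on this change, as the one step concerns another group at another place, so neither direction nor size can be taken from the data. Compound 3 is therefore expected to stay near compound 1, with an estimate of 6 mg/kg (2 mg/kg to 20 mg/kg). The expected step is a 1.2-fold higher number from compound 1 to compound 3 (0.08 log units; within the scatter), within the scatter.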

Compound 3, dose for half-maximal effect: > 10 mg/kg
Compound 3 was reported as a limit; the forecaster's own chance of this, stated with the estimate: 10%; middle value at least 1.6-fold (0.22 log units) from the limit.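

In this assay compound 3 gives > 10 mg/kg, which is a limit of the assay and not a number. From the compounds shown here alone, with 2-methoxyphenyl in place of 3-chlorophenyl on the saturated chain carbon, the data show an at least 2.0-fold higher number from compound 1 to compound 3 (0.30 log units; that floor lies within the scatter), so this change gives no lower number, and its full size remains unknown. The reading rests only on a floor: the limit of > 10 mg/kg in this assay, at which 1 of the 3 values shown sits.

The compounds shown leave open how 3-methoxyphenyl or 2-chlorophenyl would read at this place. The effect of the methoxy group therefore cannot be told apart from that of its place on the ring.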